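The compounds below may be only part of what the source reports. "The series", "measured", "known", "first", "only" and "open" are said of these compounds alone.

Compound 1 `Nc1ncnc2c1c(-c1cnc3[nH]ccc3c1)nn2CCCCCCC(=O)NO`: 30800 nM
Compound 2 `Nc1nc2cc(-c3nn(CCCCC(=O)NO)c4ncnc(N)c34)ccc2o1`: 2400 nM

In a functional assay on Bel-7402 cells (Homo sapiens) for inhibition, read by MTT assay, with a stated time of 72 h (on this read-out higher numbers stand for weaker inhibition and lower numbers for stronger inhibition), compound 1 has the higher of the two numbers at 30800 nM, so it is the weaker inhibitor, and its gap to compound 2 lies beyond the scatter. Compound 3 `Nc1nc2cc(-c3nn(CCCCCCC(=O)NO)c4ncnc(N)c34)ccc2o1` has not yet been measured. It keeps the shared core and the chain of compound 1 and differs in one group: a group of 10 heavy atoms (7 carbon, 2 nitrogen, 1 oxygen; one five-membered aromatic ring with 2 hetero atoms, one six-membered aromatic ring of carbon only) in place of a group of 9 heavy atoms (7 carbon, 2 nitrogen; one five-membered aromatic ring with 1 hetero atom, one six-membered aromatic ring with 1 hetero atom), on an aromatic carbon. Among the measured compounds shown here, no measured pair isolates this change, so its size can only be expected. Compound 2, which also carries the 2-amino-1,3-benzoxazol-5-yl group, gives 2400 nM. On that basis, a clearly lower number is expected in this assay, with a step beyond the scatter. The estimated step is a 21-fold lower number from compound 1 to compound 3 (1.31 log units; beyond the scatter). For compound 3 the expected value is 1500 nM, within an estimated range of 300 nM to 8000 nM.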

Compound 3, half-maximal inhibitory concentration: > 50000 nM
Compound 3: a limit, no number (the forecaster's own chance of this, stated with the estimate: 3%); middle value at least 33-fold (1.52 log units) from the limit.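

In this assay compound 3 gives > 50000 nM, which is a limit of the assay and not a number: the limit of > 50000 nM in this assay, at which 1 of the 3 values shown sits.

With the chain of compound 1 kept, placing 2-amino-1,3-benzoxazol-5-yl on this aromatic carbon gives an at least 1.6-fold higher number from compound 1 to compound 3 (0.21 log units; that floor lies within the scatter), so the exchange brings no lowering, while the floor alone does not establish a rise. With 2-amino-1,3-benzoxazol-5-yl held in place, 2-(hydroxycarbamoyl)ethyl in place of hydroxycarbamoyl on the chain gives an at least 20-fold higher number from compound 2 to compound 3 (1.31 log units; beyond the scatter), which shows that this group does not carry the lower number of compound 2 on its own and that the result depends on the chain as well.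

Going by these compounds, how far the number of compound 3 lies past the limit remains open. Also open, on these data alone, are how the group that leaves compound 1 behaves on the shorter chain of compound 2, and whether a carboxylic acid could replace the hydroxycarbamoyl end.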